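Bromo on the core: compound 1 to compound 4

The source may hold more compounds than are shown below. What is called first, only, known or untested is meant among the compounds shown, and "the series" means these compounds.

Within the data shown here, compound 1 `COc1cc(/C=C/c2nc3cccnc3n(CC(=O)O)c2=O)ccc1O` is the only member of the series with a number in a functional assay, read by spectrophotometry, with a stated time of 30 min, tested at 50 uM (a lower number here means a weaker effect, a higher number a stronger effect of the compound at the concentration tested), where compound 1 gives 75.6%. Compound 2 `COc1ccc(-c2nc3cccnc3n(CC(=O)O)c2=O)cc1O` has no result in this assay: for compound 2 the entry is "not determined" (no result reported). Compound 3 `COc1c(O)cc(-c2nc3cccnc3n(CC(=O)O)c2=O)cc1O` likewise carries "not determined" (no result reported) in this assay. Compound 4 `COc1cc(/C=C/c2nc3cc(Br)cnc3n(CC(=O)O)c2=O)ccc1O` has not been measured. It differs from compound 1 by bromo in place of hydrogen on an aromatic carbon. Among the measured compounds shown here, no pair of measured compounds shows what such a change does in this assay, so the step is expected to be small, with no direction beyond the scatter: the step of a number 1.6 percentage points lower from compound 1 to compound 4 (within the scatter) is the estimate. On that basis compound 4 is expected to give 74% in this assay, within a range from 55% to 90%.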

Compound 4, a percentage reported as activity, at one concentration (the size of the read-out at that concentration, not a potency): 75.4%
Estimate against measurement, compound 4: 1.4 percentage points below; the measured number falls inside the stated range.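

Bromo in place of hydrogen on an aromatic carbon, two atoms from the ring nitrogen, gives a number 0.2 percentage points lower from compound 1 to compound 4 (within the scatter) in this assay. Among these compounds, this is the only reading so far of a change on the core, and this place takes a bromine atom with no shift beyond the scatter. No measurement on hand speaks to why the reading holds. Going by these compounds, whether an amine or a nitrile at the same place would read alike stays open, as does whether bromo elsewhere on the core would.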